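Bromo for methoxy on the aryl ring of compound 2

The source may report more compounds than this note shows. Statements on the series, on what has been measured and on what is new or still open speak of the compounds shown alone.

In an assay on Sf9 cells for inhibition of protein deacetylase HDAC6 (Homo sapiens), read by fluorescence, with a stated time of 40 min, tested at 100 nM (on this read-out lower numbers stand for less inhibition and higher numbers for more inhibition at the one concentration tested (going by the name of the read-out)), compound 1 `O=C(NO)c1ccc(NCc2nc(-c3cccc4cnccc34)nn2-c2ccccc2)cc1` gives 40.2% and compound 2 `COc1ccc(-c2nc(CNc3ccc(C(=O)NO)cc3)n(-c3ccccc3)n2)cc1` gives 77.6%. Compound 2 therefore stands highest of the two numbers shown, the only measured step being a number 37.4 percentage points higher from compound 1 to compound 2 (beyond the scatter). Compound 3 `O=C(NO)c1ccc(NCc2nc(-c3ccc(Br)cc3)nn2-c2ccccc2)cc1` differs from compound 2 by bromo in place of methoxy on an aromatic carbon. Among the measured compounds shown here, no measured step bears on this exchange, since the one step known swaps the whole aryl ring rather than a group on it. A step within the scatter is therefore expected, a number 7.6 percentage points lower from compound 2 to compound 3 (within the scatter), and compound 3 is estimated at 70%, with a range from 50% to 88%.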

Compound 3, a percentage reported as inhibition, at one concentration (the size of the read-out at that concentration, not a potency): 54.7%
Compound 3: the middle estimate sits 15.3 percentage points above what was measured, within the range that was stated.
By their numbers in this assay, from the lowest: compound 1; then compound 3; then compound 2.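

In this assay, the group on this aromatic carbon matters even with the phenyl ring kept: bromo in place of methoxy gives a number 22.9 percentage points lower from compound 2 to compound 3 (beyond the scatter). The number with the 4-bromophenyl group is still higher than with isoquinolin-5-yl, with a number 14.5 percentage points higher from compound 1 to compound 3 (beyond the scatter), so only part of the gain seen with 4-methoxyphenyl survives without the methoxy. No available evidence explains this difference. As far as these compounds go, it remains open whether an amine, a hydroxy group or a longer ether such as ethoxy on this carbon would match methoxy, and whether methoxy would give the same number elsewhere on the ring.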